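Amino Replaces Hydrogen on the Anilino Ring

The source may hold more compounds than are shown below. What is called first, only, known or untested is meant among the compounds shown, and "the series" means these compounds.

Compound 1 `Fc1cccc(-c2nc(Nc3ccccc3)c3cc(F)ccc3n2)c1` gives 47600 nM.
Compound 2 `COc1ccc(Nc2nc(-c3cccc(F)c3)nc3ccc(F)cc23)cc1` gives 32300 nM.
Compound 3 `Fc1cccc(-c2nc(Nc3cccc(Br)c3)c3cc(F)ccc3n2)c1` reaches only the limit > 50000 nM, which is a limit of the assay and not a number.

All three were tested in a functional assay on U2OS cells (Homo sapiens) for cytotoxicity, read by MTT assay, with a stated time of 48 h; on this read-out lower numbers stand for stronger inhibition and higher numbers for weaker inhibition. Among the two numbers shown, compound 1 carries the higher one, and its nearest neighbour is compound 2, with a 1.5-fold lower number from compound 1 to compound 2 (0.17 log units; within the scatter). Compound 3 sits at the limit of > 50000 nM in this assay, at which 1 of the 3 values shown sits, so only an at least 1.0-fold higher number from compound 1 to compound 3 (0.02 log units; that floor lies within the scatter) and an at least 1.5-fold higher number from compound 2 to compound 3 (0.18 log units; that floor lies within the scatter) can be said of it.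

Compound 4 `Nc1ccc(Nc2nc(-c3cccc(F)c3)nc3ccc(F)cc23)cc1` has not been measured. It differs from compound 1 by amino in place of hydrogen on an aromatic carbon.

Among the compounds with values here, the step that bears most directly on this is the one from compound 1 to compound 2, where a methoxy group enters the same aromatic carbon and the number moves within the scatter. The bromo step to compound 3 ends at a limit and also stays within the scatter at its floor. Neither step gives grounds to expect the amino group to move the number beyond the scatter in either direction, so a step of a 1.1-fold lower number from compound 1 to compound 4 (0.05 log units; within the scatter) is expected. Compound 4 is therefore estimated at 42000 nM, between 15000 nM and 110000 nM.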

Compound 4, half-maximal inhibitory concentration: 44200 nM
The estimate for compound 4 lay 1.1-fold (0.02 log units) below the measured number; measured number inside the range.
By their numbers in this assay, from the lowest: compounds 2, 4 and 1 (each within the scatter of the next). At a limit, above all of these: compound 3.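

In this assay, amino on the aromatic carbon para to a large group gives a 1.1-fold lower number from compound 1 to compound 4 (0.03 log units; within the scatter), and this carbon now has two groups that can be compared directly, with a 1.4-fold higher number from compound 2 to compound 4 (0.14 log units; within the scatter). Compounds 1, 2 and 4 thus stand within the scatter of each other, which shows that hydrogen, methoxy and amino at this carbon cannot be told apart here, something the methoxy step alone could not show. Compound 3 stands at a limit of the assay and not at a number, so only an at least 1.1-fold lower number from compound 3 to compound 4 (0.05 log units; that floor lies within the scatter) can be said of the change from its 3-bromophenyl to the 4-aminophenyl, and no measurement shown accounts for how little these groups separate.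

From the compounds shown here alone, whether a carboxylic acid, a dimethylamino group or a longer chain on this same carbon would move the number beyond the scatter remains open. Going by these compounds, with the measured numbers of compounds 1, 2 and 4 all within the scatter of each other, it is also open which part of the shared core, if any, governs the number in this assay.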